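Pyrrolidine urea at the piperidine acyl position of compound 3

A few compounds are considered here, and "the series" means these few. Any claim that something is new, unique, unknown or untested is made for them only; others in the source may bear on it.

Within the data shown here, compound 3 `Cc1ccccc1C(=O)Nc1ccc(S(=O)(=O)NC2CCN(C(=O)C3CNC3)CC2)c2ccccc12` gives 1.5 nM in an assay on L1.2 cells for binding affinity to C-C chemokine receptor type 8 (Homo sapiens) (on this read-out lower numbers stand for stronger inhibition and higher numbers for weaker inhibition), the lowest of the three numbers measured so far. Compound 2 `Cc1ccccc1C(=O)Nc1ccc(S(=O)(=O)NC2CCN(C(=O)CCCN)CC2)c2ccccc12` gives 1.6 nM; the step of a 1.1-fold lower number from compound 2 to compound 3 (0.03 log units; within the scatter) lies within the scatter, so the two cannot be ordered. Compound 1 `CC(=O)N1CCC(NS(=O)(=O)c2ccc(NC(=O)c3ccccc3C)c3ccccc23)CC1` gives 6.7 nM; the steps of a 4.2-fold lower number from compound 1 to compound 2 (0.62 log units; beyond the scatter) and a 4.5-fold lower number from compound 1 to compound 3 (0.65 log units; beyond the scatter) are both beyond the scatter.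

Compound 4 `Cc1ccccc1C(=O)Nc1ccc(S(=O)(=O)NC2CCN(C(=O)N3CCCC3)CC2)c2ccccc12` differs from compound 3 by pyrrolidin-1-yl in place of azetidin-3-yl on a carbonyl carbon. Among the measured compounds shown here, no measured step is this one, but both steps from compound 1 bear on it: each adds a group with a hydrogen-bond donor on the carbonyl carbon and each gave a modest lower number. The change to compound 4 goes the other way, removing the group with 1 hydrogen-bond donor and 1 hydrogen-bond acceptor and bringing in one with none, though the new group is larger than the methyl of compound 1 and carries a ring. The expectation is therefore a step back toward the number of compound 1, of a size near a 3.3-fold higher number from compound 3 to compound 4 (0.52 log units; beyond the scatter), with wide uncertainty since no urea has been measured in the series. For compound 4 the estimate in this assay is 5 nM, within 1.5 nM to 18 nM.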

Compound 4, inhibition constant: 1.1 nM
Compound 4: middle estimate off by 4.5-fold (0.66 log units), on the high side, outside the stated range (below it).
By their numbers in this assay, from the lowest: compounds 4, 3 and 2 (each within the scatter of the next); then compound 1.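

In this assay, pyrrolidin-1-yl on this carbonyl carbon cannot be told apart from azetidin-3-yl, as a 1.4-fold lower number from compound 3 to compound 4 (0.13 log units; within the scatter) shows, or from 3-aminopropyl, as a 1.5-fold lower number from compound 2 to compound 4 (0.16 log units; within the scatter) shows, although pyrrolidin-1-yl has 0 hydrogen-bond donors. Against methyl on the same carbonyl carbon, the change gives a 6.1-fold lower number from compound 1 to compound 4 (0.78 log units; beyond the scatter) and so the lower number relative to compound 1 does not depend on a hydrogen-bond donor in the group, which the two earlier steps could not show since both groups carried one. Nothing at hand explains why these three different groups read alike.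

Still open, from the compounds shown here alone, is whether a carboxylic acid or a small open-chain group such as dimethylamino on this carbonyl carbon would stay level with compounds 2, 3 and 4 or fall back toward compound 1. Also open, going by these compounds, is whether the pyrrolidin-1-yl result carries over to any change in the shared core, as all four compounds differ only at this position.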